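The source may report more compounds than this note shows. Statements on the series, on what has been measured and on what is new or still open speak of the compounds shown alone.

Compound 1 `CN1CCN(CCCCCCn2c3c(c4ccccc42)C(=O)c2c[n+]([O-])c4ccccc4c2C3=O)CC1` gives 5800 nM in a toxicity assay on HEK-293T cells (Homo sapiens) for cytotoxicity, read by MTT assay, with a stated time of 72 h; a lower number here means a stronger inhibitor, a higher number a weaker inhibitor.
Compound 2 `O=C1c2c[n+]([O-])c3ccccc3c2C(=O)c2c1c1ccccc1n2Cc1cn(C[C@@H](O)CO)nn1` gives 2030 nM in this assay.
Compound 3 `O=C1c2c[n+]([O-])c3ccccc3c2C(=O)c2c1c1ccccc1n2Cc1cn(CC(O)CO)nn1` gives 760 nM in this assay.

Compound 3 has the lowest number of the three, with compound 2 nearest and compound 1 furthest; both gaps lie beyond the scatter. Compound 4 `CN(C)CCCCn1c2c(c3ccccc31)C(=O)c1c[n+]([O-])c3ccccc3c1C2=O` differs from compound 3 by 3-(dimethylamino)propyl in place of 1-(2,3-dihydroxypropyl)-1H-1,2,3-triazol-4-yl on a saturated chain carbon bound to an aromatic nitrogen. Compound 4 thus carries an open chain of the kind found in compound 1 rather than the ring-bearing group of compound 3. Going by the values given here, the steps that bear on this are a 7.6-fold lower number from compound 1 to compound 3 (0.88 log units; beyond the scatter) and a 2.9-fold lower number from compound 1 to compound 2 (0.46 log units; beyond the scatter), both going the opposite way, so a modest rise in this assay is expected here, roughly reversing them. Compound 4 is therefore expected to give 3500 nM, between 1200 nM and 10000 nM, a change of a 4.6-fold higher number from compound 3 to compound 4 (0.66 log units; beyond the scatter).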

Compound 4, half-maximal inhibitory concentration: 520 nM
Compound 4: middle estimate off by 6.7-fold (0.83 log units), on the high side; the whole stated range lies above it.
By their numbers in this assay, from the lowest: compounds 4 and 3 (each within the scatter of the next); then compound 2; then compound 1.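

In this assay, an open chain on this saturated chain carbon does not by itself bring a high number: replacing the triazole-bearing group with 3-(dimethylamino)propyl gives no change beyond the scatter (a 1.5-fold lower number from compound 3 to compound 4 (0.16 log units; within the scatter)). Among the open chains, the end group matters, since dimethylamino in place of 2-(4-methylpiperazin-1-yl)ethyl gives a large step (an 11-fold lower number from compound 1 to compound 4 (1.05 log units; beyond the scatter)). The same replacement starting from compound 2 does lie beyond the scatter (a 3.9-fold lower number from compound 2 to compound 4 (0.59 log units; beyond the scatter)), and the two starting compounds differ in only one respect: the fact that one of compounds 2 and 3 is drawn with a defined configuration and the other without, at the place where they differ.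

Going by these compounds, it remains open whether a morpholine in place of dimethylamino would keep the number near that of compound 4 or move it towards that of compound 1.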